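Cytotoxicity on Vero cells: a carbamate replaces an aryl amide

The source may hold more compounds than are shown below. What is called first, only, known or untested is meant among the compounds shown, and "the series" means these compounds.

Measured compounds:
Compound 1 `CCN(CC)c1cc2[nH]c(C3CCCCC3)nc2cc1NC(=O)OCCOCCOC` - > 100 ug/mL
Compound 2 `CCCc1ccc(C(=O)Nc2cc3nc(C4CCCCC4)[nH]c3cc2N(C)C)cc1` - > 100 ug/mL
Compound 3 `CCCc1ccc(C(=O)Nc2cc3nc(C4CCCCC4)[nH]c3cc2N(CC)CC)cc1` - "not determined" (no result reported)

In an ADME assay on Vero cells (Chlorocebus sabaeus) for cytotoxicity, read by resazurin assay, with a stated time of 3 days (on this read-out higher numbers stand for weaker inhibition and lower numbers for stronger inhibition), compound 1 reaches only the limit of the assay, > 100 ug/mL. Compound 2 likewise stops at the limit, > 100 ug/mL. For compound 3 the entry is "not determined" (no result reported). Compound 2 therefore stands at the limit of > 100 ug/mL in this assay, at which 2 of the 3 values shown sit, with no number of its own. Compound 4 `CCCCOC(=O)Nc1cc2nc(C3CCCCC3)[nH]c2cc1N(C)C` differs from compound 2 by butoxy in place of 4-propylphenyl on a carbonyl carbon. Among the measured compounds shown here, with no measured step to compare against, the change from compound 2 to compound 4 is expected to bring no shift beyond the usual scatter, a number no higher from compound 2 to compound 4 (the limit leaves the size open). Compound 4 is thus expected to sit near the limit as well, estimated at 100 ug/mL, between 60 ug/mL and 200 ug/mL.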

Compound 4, half-maximal inhibitory concentration: > 100 ug/mL
Compound 4: only a limit was reported; the forecaster's own chance of this, stated with the estimate: 75%; the middle value sits exactly at the limit.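

Compound 2 and compound 4 both stop at a limit rather than a number, so the step between them cannot be read: the limit of > 100 ug/mL in this assay, at which 3 of the 4 values shown sit. The compounds shown leave open whether butoxy in place of 4-propylphenyl on a carbonyl carbon changes anything in this assay.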